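This account rests on a few compounds, and the source may have more. Where it says the series, first, only, none or still open, it means among the compounds named here.

Compound 1 `COc1ccc(Oc2ccc(C(C)C)cc2-c2ccsc2S(=O)(=O)NCCNC(=S)Nc2ccc([N+](=O)[O-])cc2)cc1OC`: 5800 nM
Compound 2 `O=C(NCCNS(=O)(=O)c1ccc(-c2ccccc2O[C@H]2CC[C@H](O)CC2)s1)Nc1ccc([N+](=O)[O-])cc1`: 4100 nM
Compound 3 `COc1ccc(NC(=O)NCCNS(=O)(=O)c2sccc2-c2ccc(C)cc2Oc2ccc(O)c(O)c2)cc1`: 8200 nM

All three values come from a functional assay on RS4-11 cells (Homo sapiens) for inhibition, read by CCK-8 assay, with a stated time of 48 h; on this read-out lower numbers stand for stronger inhibition and higher numbers for weaker inhibition. Compound 3 lies within the usual scatter of both compound 1 and compound 2, so these values give no ranking. Compound 4 `Cc1ccc(-c2ccsc2S(=O)(=O)NCCNC(=O)Nc2ccc([N+](=O)[O-])cc2)c(Oc2ccc(O)c(O)c2)c1` differs from compound 3 at one place, with nitro in place of methoxy on an aromatic carbon, para to a large group: nitro in place of methoxy on an aromatic carbon. Within the data shown here, no measured pair shows this change alone. However, compound 1 at 5800 nM and compound 2 at 4100 nM both carry 4-nitrophenyl, and neither lies beyond the scatter of compound 3. No change beyond the scatter is therefore expected, and the estimated 1.5-fold lower number from compound 3 to compound 4 (0.17 log units; within the scatter) stays within it. For compound 4 the estimated value is 5500 nM, with an expected range of 2500 nM to 12000 nM.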

Compound 4, half-maximal inhibitory concentration: 7700 nM
Estimate against measurement, compound 4: 1.4-fold (0.15 log units) below, and the stated range covers the measured number.
By their numbers in this assay, from the lowest: compounds 2, 1, 4 and 3 (each within the scatter of the next).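

In this assay putting nitro in place of methoxy on this aromatic carbon, para to a large group, gives a 1.1-fold lower number from compound 3 to compound 4 (0.03 log units; within the scatter). This single-place comparison shows that, with the rest of the molecule held constant, the two groups cannot be told apart at this position. No available measurement explains this result.

The compounds shown leave open whether an amine or a carboxylic acid on this carbon would also stay within the scatter. They also leave open whether the same change would read alike on the core of compound 2.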